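This account rests on a few compounds, and the source may have more. Where it says the series, first, only, none or still open, it means among the compounds named here.

Compound 1 `CC(C)=CCC[C@]1(C)/C=C/[C@@H](OC(=O)C=C(C)C)[C@](C)(O)/C=C/C(=O)/C(COC(=O)c2ccc([N+](=O)[O-])cc2)=C\C1`: 670 nM
Compound 2 `CC(C)=CCC[C@]1(C)/C=C/[C@@H](OC(=O)C=C(C)C)[C@](C)(O)/C=C/C(=O)/C(CN=[N+]=[N-])=C\C1`: 4890 nM

Both compounds were measured in a functional assay on MCF7 cells (Homo sapiens) for antiproliferative activity, read by MTT assay, with a stated time of 48 h; a higher number here means a weaker inhibitor, a lower number a stronger inhibitor. Compound 2, at 4890 nM, holds the higher of the two numbers, which makes it the weaker inhibitor of this pair, and its gap to compound 1 lies beyond the scatter.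

Compound 3 `CC(C)=CCC[C@]1(C)/C=C/[C@@H](OC(=O)C=C(C)C)[C@](C)(O)/C=C/C(=O)/C(Cn2cc(CO)nn2)=C\C1` departs from compound 2 at one place, with 4-(hydroxymethyl)-1H-1,2,3-triazol-1-yl in place of azido on a saturated chain carbon bound to a double-bonded ring carbon.

Going by the values given here, only one measured step bears on this place: a 7.3-fold higher number from compound 1 to compound 2 (0.86 log units; beyond the scatter). That modest step, from ((4-nitrophenyl)carbonyl)oxy to azido, shows that this assay responds to a change here. It cannot speak directly for the new group, since no triazole has yet been measured. The entering group bears a ring, as the group in compound 1 does, so a small move toward lower numbers is expected, though it may not clear the scatter. The expected change is a 1.6-fold lower number from compound 2 to compound 3 (0.21 log units; within the scatter). For compound 3 the estimate is 3000 nM, with an expected range from 1000 nM to 9000 nM.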

Compound 3, half-maximal inhibitory concentration: 2930 nM
Compound 3: the middle estimate sits 1.0-fold (0.01 log units) above what was measured; the measured number falls inside the stated range.
By their numbers in this assay, from the lowest: compound 1; then compounds 3 and 2 (each within the scatter of the next).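

In this assay, the step from azido to 4-(hydroxymethyl)-1H-1,2,3-triazol-1-yl on a saturated chain carbon bound to a double-bonded ring carbon is a 1.7-fold lower number from compound 2 to compound 3 (0.22 log units; within the scatter), so the two groups cannot be told apart here even though the entering group brings a five-membered aromatic ring. The comparison with the ester is a 4.4-fold higher number from compound 1 to compound 3 (0.64 log units; beyond the scatter), which shows that a ring in this place does not by itself bring the number to that of compound 1, and with both of its steps beyond the scatter, compound 1 remains the strongest inhibitor of the three. No separate measurement is available to explain these readings.

The compounds shown leave open which part of the ((4-nitrophenyl)carbonyl)oxy group goes with the lower number of compound 1, a question that a plain benzoyloxy group without the nitro group, or a simple acetoxy group, would help to settle. From the compounds shown here alone, it also remains open whether the hydroxymethyl group on the triazole matters, which a triazole carrying a phenyl ring, an amine or a carboxylic acid in its place would test.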